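Amide nitrogen substitution in the tricyclic carboxamide series

The compounds below may be only part of what the source reports. "The series", "measured", "known", "first", "only" and "open" are said of these compounds alone.

Measured so far:
- compound 1, `COC(=O)C12CCCC3CC(CCC31)C2`: 80000 nM
- compound 2, `CNC(=O)C12CCCC3CC(CCC31)C2`: 750000 nM

In an ADME assay (Gallus gallus) for cytotoxicity, read by microscopy, with a stated time of 24 h (a higher number here means that more compound is tolerated, a lower number that less compound is tolerated), compound 1 gives 80000 nM, while compound 2 gives 750000 nM. Going by the values given here, the one step so far, a 9.4-fold higher number from compound 1 to compound 2 (0.97 log units; beyond the scatter), concerns the group on the carbonyl carbon. Compound 2 thus stands at the higher of the two numbers in this assay, with compound 1 the nearest neighbour.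

Compound 3, `O=C(NC1CCCCC1)C12CCCC3CC(CCC31)C2`, keeps the amide of compound 2 and differs from it only in this way: cyclohexyl in place of methyl on an amide-type nitrogen. Among the compounds with values here, no measured step touches the amide nitrogen, so the measured step from compound 1 to compound 2 does not bear directly on this change; it only shows that the series responds to changes at the amide in this assay. With nothing measured to anchor the direction, the expectation for compound 3 is a step of a 2.5-fold lower number from compound 2 to compound 3 (0.40 log units; beyond the scatter), worded loosely and with a wide range. Compound 3 is expected to give 300000 nM in this assay, within 80000 nM to 800000 nM.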

Compound 3, minimum cytotoxic concentration: 2250000 nM
Compound 3: the middle estimate sits 7.5-fold (0.88 log units) below what was measured; measured number outside the range, above it.
By their numbers in this assay, from the lowest: compound 1; then compound 2; then compound 3.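

The amide nitrogen now has a measured step of its own: in this assay the change to cyclohexyl in place of methyl gives a 3.0-fold higher number from compound 2 to compound 3 (0.48 log units; beyond the scatter) and so adds to the earlier change on the carbonyl carbon. At this position, going from 1 heavy atom to 6 heavy atoms in one six-membered non-aromatic ring does not lower the number, and compound 3 stands highest of the three compounds shown. No measured evidence on these compounds accounts for the rise.

From the compounds shown here alone, a single pair cannot separate the effect of the ring from that of the added carbons, so it remains open whether a longer open chain on the nitrogen would give the same rise. Also open, going by these compounds, is how a phenyl ring, or a cyclohexyl carrying an amine or a carboxylic acid, would read here.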